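Methoxycarbonyl gives way to tert-butyl in compound 4

The source may report more compounds than this note shows. Statements on the series, on what has been measured and on what is new or still open speak of the compounds shown alone.

Values in an ADME assay on HEK293 cells (Homo sapiens) for cytotoxicity, with a stated time of 72 h; a higher number here means that more compound is needed for the effect, a lower number that less compound is needed:
Compound 1 `Cc1cc(NC(=O)Nc2ccccc2N)c2ccccc2n1`: > 25000 nM (a limit)
Compound 2 `COC(=O)c1cccc(NC(=O)Nc2cc(C)nc3ccccc23)c1`: 26000 nM
Compound 3 `Cc1cc(NC(=O)Nc2ccccc2C(F)(F)F)c2ccccc2n1`: > 25000 nM (a limit)

Among the measured compounds shown here, compound 2, at 26000 nM, holds the only true number in this small set. The other two values are limits of the assay, so the evidence rests largely on (the limit of > 25000 nM in this assay, at which 2 of the 3 values shown sit).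

Compound 4 `Cc1cc(NC(=O)Nc2cccc(C(C)(C)C)c2)c2ccccc2n1` takes tert-butyl in place of methoxycarbonyl on an aromatic carbon, and the shared core stays the same: tert-butyl in place of methoxycarbonyl on an aromatic carbon. For the measured compounds named here, no measured step covers this exchange. Going by the values given here, the one step available is a step that the two limits leave unreadable from compound 1 to compound 3, which concerns a different exchange and gives no size to carry over. No step beyond the scatter is therefore expected, and compound 4 should stay close to compound 2 at 26000 nM. The expected change is a 1.2-fold lower number from compound 2 to compound 4 (0.07 log units; within the scatter). For compound 4 the estimated value is 22000 nM, with an expected range of 9000 nM to 40000 nM. Compound 4 may equally be reported only as a limit.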

Compound 4, half-maximal effective concentration: > 25000 nM
Compound 4: a limit, no number (the forecaster's own chance of this, stated with the estimate: 50%); middle value at least 1.1-fold (0.05 log units) away from the limit.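

In this assay, among the compounds shown here, compound 4 gives > 25000 nM, a limit and not a number, so no step from compound 2 to compound 4 can be read. The compounds shown leave open how far any of these exchanges shifts the value, because most results rest on one limit: the limit of > 25000 nM in this assay, at which 3 of the 4 values shown sit.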